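This account rests on a few compounds, and the source may have more. Where it says the series, first, only, none or still open, it means among the compounds named here.

Working notes on the series. Compound 1 `Nc1ccc(-c2cn(Cc3cc(C(=O)O)cc(-c4ccccc4C(=O)O)c3)nn2)cc1` serves as the reference point. In an assay on cells for inhibition of ubiquitin carboxyl-terminal hydrolase isozyme L5 (Homo sapiens), read by fluorescence, with a stated time of 30 min (a higher number here means a weaker inhibitor, a lower number a stronger inhibitor), compound 1 gives 80500 nM. Compound 2 `Nc1ccc(-c2cn(Cc3cccc(-c4ccccc4C(=O)O)c3)nn2)cc1` gives 116000 nM and compound 3 `NS(=O)(=O)Nc1ccc(-c2cn(Cc3cc(C(=O)O)cc(-c4ccccc4C(=O)O)c3)nn2)cc1` gives 84500 nM. Compound 1 carries the smallest of the three numbers, but the other two lie within the scatter of it: the step of a 1.4-fold higher number from compound 1 to compound 2 (0.16 log units; within the scatter) removes a carboxy group from the benzylic ring, and the step of a 1.0-fold higher number from compound 1 to compound 3 (0.02 log units; within the scatter) places a sulfamoyl group on the aniline nitrogen. Neither change moved the number beyond the scatter.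

Compound 4 `Nc1ccc(-c2cn(Cc3cc(C(=O)O)cc(-c4cccc(C(=O)O)c4)c3)nn2)cc1` differs from compound 1 by 3-carboxyphenyl in place of 2-carboxyphenyl on an aromatic carbon. For the measured compounds named here, no measured step touches the carboxyphenyl arm itself, so the two steps bear on it only indirectly, as evidence that this region of the series has so far tolerated changes without a shift beyond the scatter. The expectation is therefore a step of a 1.1-fold higher number from compound 1 to compound 4 (0.02 log units; within the scatter), with no shift beyond the scatter foreseen. Compound 4 is estimated at 85000 nM, within a range of 40000 nM to 180000 nM, before the measurement is known.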

Compound 4, half-maximal inhibitory concentration: 32900 nM
Estimate against measurement, compound 4: 2.6-fold (0.41 log units) above, and the stated range ends above it.
By their numbers in this assay, from the lowest: compound 4; then compounds 1, 3 and 2 (each within the scatter of the next).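

For the compounds shown here, the carboxyphenyl arm is the first place where a change moves the number in this assay beyond the scatter, a 2.4-fold lower number from compound 1 to compound 4 (0.39 log units; beyond the scatter) and a modest step. The two arms have the same atoms and the same counts, and they differ only in where the carboxy group sits, so placement on this ring alone is enough to shift the number, unlike the removal of the carboxy group and the addition of sulfamoyl, which stayed within the scatter. Nothing available here bears on the reason for this shift.

Going by these compounds, whether the shift with the 3-carboxyphenyl arm depends on the carboxy group of the benzylic ring remains open. Also open, on these data alone, is whether the arm needs a carboxylic acid at all, or whether an amide or a hydroxymethyl group in its place would give a similar number.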